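Benzyl replacement in the pyridone amide series: lipophilicity note

The source may report more compounds than this note shows. Statements on the series, on what has been measured and on what is new or still open speak of the compounds shown alone.

Compound 1 `CNC(=O)c1cc(C(=O)NC2CC2)cn(Cc2ccc(OC)cc2)c1=O` is the reference point of this set. In a physicochemical assay for lipophilicity, at pH 7.4 (a higher number here means a more lipophilic compound, a lower number a more polar compound), compound 1 gives 3, the highest of the three numbers at hand. Compound 3 `CNC(=O)c1cc(C(=O)NC2CC2)cn(Cc2cccc3[nH]c(C)nc23)c1=O` gives 1.5 in this assay, and compound 2 `CNC(=O)c1cc(C(=O)NCCCC2CNCCO2)cn(Cc2ccccc2)c1=O` gives 1.4; both gaps from compound 1 lie beyond the scatter of the measurement, so compound 1 is clearly the most lipophilic of the measured compounds. Among the measured compounds shown here, no single-point steps between measured compounds are available, so the new step is judged from the structures alone.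

Compound 4 `CNC(=O)c1cc(C(=O)NC2CC2)cn(Cc2ccccc2F)c1=O` differs from compound 1 in one place: 2-fluorophenyl in place of 4-methoxyphenyl on a saturated chain carbon bound to an aromatic nitrogen. The group that leaves carries one hydrogen-bond acceptor and the group that enters carries none, with one heavy atom fewer overall. The step from compound 1 to compound 4 is expected to be small, with no change beyond the scatter, at a number 0.10 log units higher from compound 1 to compound 4 (within the scatter). Compound 4 is therefore estimated at 3.1 in this assay, within a range of 2.7 to 3.5.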

Compound 4, distribution coefficient: 3
The estimate for compound 4 lay 0.10 log units above the measured number; the range from low to high includes it.
By their numbers in this assay, from the lowest: compounds 2 and 3 (each within the scatter of the next); then compounds 1 and 4 (each within the scatter of the next).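

Among the compounds shown here, on the saturated chain carbon bound to an aromatic nitrogen, 2-fluorophenyl in place of 4-methoxyphenyl gives the first single-place step in the set, and this assay shows no change at the digits printed from compound 1 to compound 4 (within the scatter) for it. This place therefore accepts a swap from a group with one hydrogen-bond acceptor to a group with none, and one heavy atom fewer, without a shift beyond the scatter in this pair. No measurement at hand explains this result.

From the compounds shown here alone, whether an amine, a carboxylic acid or a longer chain on the aromatic ring would move the number at this place remains open. This single pair also cannot separate the loss of the methoxy group from the gain of the fluorine.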